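This account rests on a few compounds, and the source may have more. Where it says the series, first, only, none or still open, it means among the compounds named here.

Measured compounds:
compound 1 `CC(=O)Oc1ccc2cc(-c3cccs3)c(=O)oc2c1OC(C)=O`: in an assay on CHO cells for displacement of a labelled ligand from transmembrane domain-containing protein TMIGD3 (Homo sapiens) (a lower number here means a stronger inhibitor, a higher number a weaker inhibitor), compound 1 gives 22500 nM
compound 2 `CC(=O)Oc1cccc2cc(-c3cc(Br)cs3)c(=O)oc12`: in this assay compound 2 gives 4080 nM

Of the two numbers, compound 2 holds the lower one; compound 1 sits clearly higher, a gap beyond the usual scatter. Compound 1 and compound 2 differ in two places at once, so the two values do not isolate either change.

The next compound is compound 3 `CC(=O)Oc1ccc2cc(-c3cc(Br)cs3)c(=O)oc2c1OC(C)=O`. It follows from compound 2 by acetoxy in place of hydrogen on an aromatic carbon, so that compound 3 carries the bromine of compound 2 together with the two acetoxy groups of compound 1. Going by the values given here, no measured pair shows this single change on its own. Among the compounds with values here, what the data do show is that compound 1, the only compound with the second acetoxy group, gives the higher number in this assay; that compound also lacks the bromine, so the share of each change is open. A moderate move toward a higher number seems the likelier outcome, with a wide range allowed.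

Compound 3 is expected to come in around 8000 nM, between 2500 nM and 25000 nM. The step this expectation implies is a 2.0-fold higher number from compound 2 to compound 3 (0.29 log units; within the scatter).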

Compound 3, inhibition constant: > 100000 nM
Compound 3: a limit, no number; the forecaster's own chance of this, stated with the estimate: 10%; at least 12-fold (1.09 log units) between middle value and limit.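

Compound 3 is reported in this assay only as a limit of the assay, not as a number: the limit of > 100000 nM in this assay, at which 1 of the 3 values shown sits.

Acetoxy in place of hydrogen on this aromatic carbon, ortho to the existing acetoxy group, gives an at least 24-fold higher number from compound 2 to compound 3 (1.38 log units; beyond the scatter). Going by these compounds alone, this is the first reading of this single change on its own, and it shows that the position tolerates the added acetoxy group poorly when the bromine is present. With both acetoxy groups held fixed, bromo in place of hydrogen gives an at least 4.4-fold higher number from compound 1 to compound 3 (0.64 log units; beyond the scatter), so on this background the bromine moves the number upward, and both single changes in the series now point toward a weaker inhibitor.

Within the data shown here, whether the bromine has the same effect with only one acetoxy group stays open, as does how far the true value of compound 3 lies beyond its limit. As far as these compounds go, it is also open whether a smaller or differently linked group at this position, such as a hydroxyl, a methoxy group or an amine in place of the added acetoxy group, would keep the number near that of compound 2.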